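Methoxy in place of pyrrolidin-1-yl on the chain

This account rests on a few compounds, and the source may have more. Where it says the series, first, only, none or still open, it means among the compounds named here.

In a functional assay on HCT-116 cells (Homo sapiens) for antiproliferative activity, read by sulforhodamine B assay, with a stated time of 72 h (on this read-out higher numbers stand for weaker inhibition and lower numbers for stronger inhibition), compound 1 (`Cn1ncc(Cl)c1-c1cc(C(=O)N[C@@H]2CN[C@H](CCn3cncn3)C[C@H]2c2ccc(Cl)c(Cl)c2)oc1Cl`) gives 560 nM, while compound 2 (`Cn1ncc(Cl)c1-c1cc(C(=O)N[C@@H]2CN[C@H](CCN3CCCC3)C[C@H]2c2ccc(Cl)c(Cl)c2)oc1Cl`) gives 1940 nM, the higher of the two numbers. Compound 3 (`COCC[C@@H]1C[C@@H](c2ccc(Cl)c(Cl)c2)[C@H](NC(=O)c2cc(-c3c(Cl)cnn3C)c(Cl)o2)CN1`) carries methoxy in place of pyrrolidin-1-yl on a saturated chain carbon, two bonds along the chain from a saturated ring carbon. Among the compounds with values here, the only measured step at this place, a 3.5-fold higher number from compound 1 to compound 2 (0.54 log units; beyond the scatter), is modest and beyond the scatter. Within the data shown here, no measured compound carries methoxy, so a modest step towards lower numbers in this assay is expected, though with little certainty. The expected change is a 2.2-fold lower number from compound 2 to compound 3 (0.33 log units; beyond the scatter). The estimate for compound 3 is 900 nM, within a range of 350 nM to 2200 nM.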

Compound 3, half-maximal inhibitory concentration: 470 nM
For compound 3 the middle estimate is 1.9-fold (0.28 log units) above the measured one; low and high end bracket the measured number.
By their numbers in this assay, from the lowest: compounds 3 and 1 (each within the scatter of the next); then compound 2.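

In this assay, methoxy in place of pyrrolidin-1-yl gives a 4.1-fold lower number from compound 2 to compound 3 (0.62 log units; beyond the scatter), so this position tolerates a chain end without a ring as well as one with a ring. Methoxy and 1H-1,2,4-triazol-1-yl cannot be told apart, with a 1.2-fold lower number from compound 1 to compound 3 (0.08 log units; within the scatter), which leaves pyrrolidin-1-yl as the only one of the three groups with a higher number. Nothing at hand explains this difference. The compounds shown leave open how a hydroxy group, a morpholin-4-yl group or a longer ether chain would read at this place.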